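Swapping the Aryl Group on the Amine: What to Expect

The source may report more compounds than this note shows. Statements on the series, on what has been measured and on what is new or still open speak of the compounds shown alone.

Compound 1 `C=C1[C@@H](OC(C)=O)C[C@@H]2[C@](C)(COC=O)[C@H](OC(C)=O)CC[C@@]2(C)[C@@H]1C[C@@H](Nc1ccc(Br)cc1)C1=CCOC1=O`: 15900 nM
Compound 2 `C=C1[C@@H](OC(C)=O)C[C@@H]2[C@](C)(COC=O)[C@H](OC(C)=O)CC[C@@]2(C)[C@@H]1C[C@@H](Nc1ccc(OC)cc1)C1=CCOC1=O`: 28900 nM

Of the compounds shown here, two sharing one core have been measured in a functional assay on A549 cells (Homo sapiens) for cytotoxicity, read by sulforhodamine B assay; a lower number here means a stronger inhibitor, a higher number a weaker inhibitor. Among the measured compounds shown here, compound 2 gives the higher of the two numbers, yet its only neighbour is compound 1, and the step of a 1.8-fold higher number from compound 1 to compound 2 (0.26 log units; within the scatter) lies within the scatter, so no order between them can be claimed. Compound 3 `C=C1[C@@H](OC(C)=O)C[C@@H]2[C@](C)(COC=O)[C@H](OC(C)=O)CC[C@@]2(C)[C@@H]1C[C@@H](Nc1cccc(F)c1)C1=CCOC1=O` differs from compound 2 in one place: 3-fluorophenyl in place of 4-methoxyphenyl on an amine nitrogen. For the measured compounds named here, the single measured step that bears on this change is a 1.8-fold higher number from compound 1 to compound 2 (0.26 log units; within the scatter), which exchanged one aromatic substituent for another without carrying the number beyond the scatter. A halogen returns in compound 3, fluorine rather than bromo, so the step of a 1.4-fold lower number from compound 2 to compound 3 (0.16 log units; within the scatter) is expected to be modest, leaning toward a lower number but not clearly beyond the scatter. Compound 3 is therefore estimated at 20000 nM, with a range of 8000 nM to 50000 nM.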

Compound 3, half-maximal inhibitory concentration: 23200 nM
Compound 3: middle estimate off by 1.2-fold (0.06 log units), on the low side, and the stated range covers the measured number.
By their numbers in this assay, from the lowest: compounds 1, 3 and 2 (each within the scatter of the next).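

In this assay, replacing the 4-methoxyphenyl on the amine nitrogen with 3-fluorophenyl gives a 1.2-fold lower number from compound 2 to compound 3 (0.10 log units; within the scatter), and replacing the 4-bromophenyl of compound 1 with the same group gives a 1.5-fold higher number from compound 1 to compound 3 (0.16 log units; within the scatter). Compound 3 thus shows something that compound 1 and compound 2 could not: a different substituent carried under a different name of ring position, 3-fluoro rather than 4-substituted, still leaves the number within the scatter of both earlier compounds, so the three can be placed in no order. No measurement shown offers a cause for this result.

As far as these compounds go, whether any group on this nitrogen can carry the number beyond the scatter remains open. A pyridine ring or a plain alkyl chain in place of the substituted phenyl would test that, as would a carboxylic acid on the phenyl ring.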